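Swapping methyl for isopropyl on compound 3

The source may report more compounds than this note shows. Statements on the series, on what has been measured and on what is new or still open speak of the compounds shown alone.

In an ADME assay on L02 cells (Homo sapiens) for inhibition, read by CCK-8 assay, with a stated time of 48 h (on this read-out lower numbers stand for stronger inhibition of growth and higher numbers for weaker inhibition of growth), compound 1 (`CN1CCN(c2ccc(Nc3ncc(Cl)c(Nc4ccccc4)n3)nc2)CC1`) reads 7990 nM and compound 2 (`CN1CCN(c2ccc(Nc3ncc(Cl)c(NCc4ccccc4)n3)nc2)CC1`) reads 20300 nM on the same scale. Compound 3 (`Cc1cccc(Nc2nc(Nc3ccc(N4CCN(C)CC4)cn3)ncc2Cl)c1`) reads 6080 nM here. That puts it within the scatter of compound 1, and the benzyl analogue lies further off, with a 3.3-fold lower number from compound 2 to compound 3 (0.52 log units; beyond the scatter) in between.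

In compound 4 (`CC(C)c1cccc(Nc2nc(Nc3ccc(N4CCN(C)CC4)cn3)ncc2Cl)c1`) isopropyl takes the place of methyl on an aromatic carbon (isopropyl in place of methyl on an aromatic carbon) meta to a large group. Within the data shown here, the nearest precedent is methyl in place of hydrogen on an aromatic carbon, which gave a 1.3-fold lower number from compound 1 to compound 3 (0.12 log units; within the scatter) in this series. The larger 2.5-fold higher number from compound 1 to compound 2 (0.40 log units; beyond the scatter) belongs to a different change, benzyl in place of phenyl on a nitrogen, and bears on this one only loosely. Among the measured compounds shown here, no measured compound carries anything larger than methyl on this carbon, so the direction remains open.

The expected change is a 1.1-fold lower number from compound 3 to compound 4 (0.04 log units; within the scatter) in this assay and so no step beyond the scatter is foreseen. For compound 4 the estimated value is 5500 nM (expected range 2800 nM to 11000 nM).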

Compound 4, concentration for 50% growth inhibition: 12500 nM
Estimate against measurement, compound 4: 2.3-fold (0.36 log units) below; the measured number lies above the stated range.
By their numbers in this assay, from the lowest: compounds 3, 1, 4 and 2 (each within the scatter of the next, the first and the last beyond it).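

In this assay, isopropyl on this aromatic carbon gives a step beyond the scatter, a 2.1-fold higher number from compound 3 to compound 4 (0.31 log units; beyond the scatter), whereas methyl in place of hydrogen had stayed within it, so this position does respond to a change of group once the group is larger than methyl. Set against the compound with hydrogen at this carbon, however, the isopropyl change stays within the scatter, a 1.6-fold higher number from compound 1 to compound 4 (0.19 log units; within the scatter), and the exchange of benzyl for 3-isopropylphenyl does too, a 1.6-fold lower number from compound 2 to compound 4 (0.21 log units; within the scatter). No measurement among those shown gives a cause for the step from methyl to isopropyl.

From the compounds shown here alone, with only hydrogen, methyl and isopropyl at this carbon, the shape of the trend remains open. An ethyl or tert-butyl group there would show whether the number climbs with the carbon count, and a methoxy group whether a carbon-only substituent matters.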